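The source may report more compounds than this note shows. Statements on the series, on what has been measured and on what is new or still open speak of the compounds shown alone.

Compound 1, `Cc1cccc(/C=N/Nc2ncc3c(n2)n(C2CCCC2)c(=O)c(=O)n3C)c1`: 34500 nM
Compound 2, `Cc1ccc(/C=N/Nc2ncc3c(n2)n(C2CCCC2)c(=O)c(=O)n3C)cc1C`: 30200 nM
Compound 3, `Cn1c(=O)c(=O)n(C2CCCC2)c2nc(N/N=C/c3cccc([N+](=O)[O-])c3)ncc21`: 12300 nM

All three were tested in a functional assay on A549 cells (Homo sapiens) for antiproliferative activity, read by MTT assay; on this read-out lower numbers stand for stronger inhibition and higher numbers for weaker inhibition. Among these three numbers compound 1 gives the highest. Compound 2 sits nearest to it, with a 1.1-fold lower number from compound 1 to compound 2 (0.06 log units; within the scatter), a change so small that the two compounds cannot be told apart. Compound 3 sits furthest, with a 2.8-fold lower number from compound 1 to compound 3 (0.45 log units; beyond the scatter). Compound 2 and compound 3 are separated by a 2.5-fold lower number from compound 2 to compound 3 (0.39 log units; beyond the scatter).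

Compound 4, `CSc1ccc(/C=N/Nc2ncc3c(n2)n(C2CCCC2)c(=O)c(=O)n3C)cc1`, has not yet been measured in this assay. It differs from compound 1 in one place: 4-(methylsulfanyl)phenyl in place of 3-methylphenyl on a carbon with a double bond to nitrogen. Among the compounds with values here, no measured step introduces a methylsulfanyl group, so only indirect guidance exists. Adding a methyl to the ring of compound 1 left the number within the scatter, and exchanging the methyl for a nitro group lowered it modestly. Both measured changes on that ring were therefore small, and a change of similar scale is expected here, most likely a small move downward or none beyond the scatter.

Compound 4 is estimated at 25000 nM, with a likely range from 10000 nM to 60000 nM. This estimate corresponds to an expected step of a 1.4-fold lower number from compound 1 to compound 4 (0.14 log units; within the scatter).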

Compound 4, half-maximal inhibitory concentration: 14100 nM
Beside the measured number, compound 4's estimate is 1.8-fold (0.25 log units) above it; the measured number falls inside the stated range.
By their numbers in this assay, from the lowest: compounds 3 and 4 (each within the scatter of the next); then compounds 2 and 1 (each within the scatter of the next).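

In this assay the 4-(methylsulfanyl)phenyl group gives a clear move away from the methyl-only rings, with both steps modest but beyond the scatter (a 2.4-fold lower number from compound 1 to compound 4 (0.39 log units; beyond the scatter) and a 2.1-fold lower number from compound 2 to compound 4 (0.33 log units; beyond the scatter)). Within the data shown here, it also lands level with the nitro compound (a 1.1-fold higher number from compound 3 to compound 4 (0.06 log units; within the scatter)), so a nitro group is not the only group on the ring of the carbon with a double bond to nitrogen that comes with a lower number, and the two groups cannot be told apart here. Why these two different groups end up at the same level cannot be said, since nothing measured on these compounds speaks to a cause.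

This change swaps the group and its place on the ring at once, so the compounds shown cannot separate the effect of the sulfur from the effect of where the group sits, and a 4-methylphenyl or a 3-(methylsulfanyl)phenyl would pull those two apart. As far as these compounds go, how the number responds to an amine or a carboxylic acid on that ring, or to a longer sulfur chain such as ethylsulfanyl, also remains open.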